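This account rests on a few compounds, and the source may have more. Where it says the series, first, only, none or still open, it means among the compounds named here.

Measured compounds:
compound 1 `O=C(CCc1ccc2[nH]c(-c3ccc(Cl)s3)nc2c1)Nc1ccc(N2CCOCC2=O)cc1F`, in an assay on isolated protein for inhibition of Trypsin (Homo sapiens); on this read-out higher numbers stand for weaker inhibition and lower numbers for stronger inhibition > 10000 nM, a limit of the assay.
compound 2 `CC[C@@H](NC(=O)c1ccc(Cl)s1)C(=O)Nc1ccc(N2CCOCC2=O)cc1`, in this assay > 10000 nM, also a limit.
compound 3 `CCC[C@@H](NC(=O)c1ccc(Cl)s1)C(=O)Nc1ccc(N2CCOCC2=O)c(C)c1`, in this assay > 10000 nM, likewise a limit.

Where compound 3 stands is therefore not a number but a boundary: in this assay every value shown sits at the limit of > 10000 nM in this assay, at which 3 of the 3 values shown sit, and compound 3 cannot be set apart from compound 1 or compound 2 on this read-out. Going by the values given here, no step between two measured compounds is available, so nothing within the set tells how a single change moves the value.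

Compound 4 `CC[C@@H](NC(=O)c1ccc(Cl)s1)C(=O)Nc1ccc(N2CCOCC2=O)c(C)c1` is the next compound, still without a measurement in this assay. It differs from compound 3 in one place, (hydrogen in place of methyl on a saturated chain carbon, three bonds along the chain from an amide-type nitrogen and a carbonyl carbon). Compound 2 carries the same short chain as compound 4, and its value in this assay is a limit as well; what the two values show is that both compound 2 and compound 3 stay beyond the boundary.

Since all three measured compounds stay at the limit, the expected step in this assay is a step that the limit leaves unreadable from compound 3 to compound 4, that is, none beyond the scatter. For compound 4 the expected value in this assay is 15000 nM, with a range from 5000 nM to 50000 nM, and most likely it is again reported only as a limit.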

Compound 4, half-maximal inhibitory concentration: > 10000 nM
Compound 4: no number, only a limit; the forecaster's own chance of this, stated with the estimate: 85%; the middle value lies beyond the limit too.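

In this assay compound 4 gives > 10000 nM, which is a limit of the assay. Going by these compounds alone, no step from compound 3 or compound 2 to compound 4 can be read. The values shown all sit at one boundary: the limit of > 10000 nM in this assay, at which 4 of the 4 values shown sit. The compounds shown leave open how strongly any of them inhibits, and which change, if any, would bring a value inside the limit.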